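The source may report more compounds than this note shows. Statements on the series, on what has been measured and on what is new or still open speak of the compounds shown alone.

Compound 1 `CCO/N=C/c1c(N)ncnc1Oc1ccc(NC(=O)C2(C(=O)Nc3ccc(F)cc3)CC2)cc1F` has the highest of the three numbers measured in a physicochemical assay for lipophilicity, using the shake flask method (on this read-out higher numbers stand for higher lipophilicity and lower numbers for lower lipophilicity), where compound 1 gives 3.41. Compound 3 `C#CCO/N=C/c1c(N)ncnc1Oc1ccc(NC(=O)C2(C(=O)Nc3ccc(F)cc3)CC2)cc1F` lies nearest, compound 3 giving 3.34 after a step of a number 0.07 log units lower from compound 1 to compound 3 (within the scatter). Compound 2 `Nc1ncnc(Oc2ccc(NC(=O)C3(C(=O)Nc4ccc(F)cc4)CC3)cc2F)c1/C=N/O` lies furthest, compound 2 giving 2.62 after a step of a number 0.79 log units lower from compound 1 to compound 2 (beyond the scatter). Compound 4 `CC(O)CO/N=C/c1c(N)ncnc1Oc1ccc(NC(=O)C2(C(=O)Nc3ccc(F)cc3)CC2)cc1F` differs from compound 1 by 1-hydroxyethyl in place of methyl on a saturated chain carbon bound to an oxygen on an unsaturated carbon. For the measured compounds named here, no measured step puts a 1-hydroxyethyl on this carbon; the steps of a number 0.79 log units lower from compound 1 to compound 2 (beyond the scatter) and a number 0.72 log units higher from compound 2 to compound 3 (beyond the scatter) show only what shortening or lengthening the chain does, and both were modest. The entering group is expected to lower the number by about as much as the shortening did, so compound 4 is estimated at 2.65, between 2.25 and 3.05, an expected step of a number 0.76 log units lower from compound 1 to compound 4 (beyond the scatter).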

Compound 4, partition coefficient: 2.75
Beside the measured number, compound 4's estimate is 0.10 log units below it, within the range that was stated.
By their numbers in this assay, from the lowest: compounds 2 and 4 (each within the scatter of the next); then compounds 3 and 1 (each within the scatter of the next).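

In this assay, the 2-hydroxypropyl chain on this oxygen gives a number 0.66 log units lower from compound 1 to compound 4 (beyond the scatter) and a number 0.59 log units lower from compound 3 to compound 4 (beyond the scatter), so not every chain longer than ethyl keeps the number near those of compound 1 and compound 3. Chain length alone therefore does not set the number: a number 0.13 log units higher from compound 2 to compound 4 (within the scatter) leaves 2-hydroxypropyl within the scatter of hydrogen on this oxygen. Nothing available explains these steps. The compounds shown leave open whether a 2-methoxypropyl chain would read like compound 4 or like compound 1. They also leave open how an amine or a carboxylic acid on this chain would read.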